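The compounds below may be only part of what the source reports. "The series", "measured", "known", "first", "only" and "open" are said of these compounds alone.

Measured compounds in a functional assay on CHO cells for activation of 5-hydroxytryptamine receptor 1D (Homo sapiens), read by GTPgammaS binding; on this read-out lower numbers stand for smaller maximal responses and higher numbers for larger maximal responses:
- compound 1 `O[C@@H]1Cc2ccccc2[C@H]1NC1CCN(CCCc2c[nH]c3ccc(-n4cnnc4)cc23)CC1` gives 75%
- compound 2 `OC[C@H](NC1CCN(CCCc2c[nH]c3ccc(Cn4cncn4)cc23)CC1)c1ccccc1` gives 76%
- compound 3 `C[C@@H](NC1CCN(CCCc2c[nH]c3ccc(-n4ccnc4)cc23)CC1)c1ccccc1` gives 65%

Compound 1 stands second highest of the three numbers in this assay. Its nearest neighbour is compound 2, whose maximal response lies within the usual scatter of that of compound 1; the furthest is compound 3, whose maximal response also lies within the scatter of that of compound 1. So the three measured compounds, which differ from each other in several places at once, all sit in one band of maximal response, and no ordering among them can be read from the numbers.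

Compound 4 `CN(Cc1ccccc1)CC1CCN(CCCc2c[nH]c3ccc(-n4cnnc4)cc23)CC1` has not been measured in this assay. Against compound 1 the change is (benzyl(methyl)amino)methyl in place of (2-hydroxy-2,3-dihydro-1H-inden-1-yl)amino on a saturated ring carbon. The hydroxy group and the ring-bound amine hydrogen both depart; a tertiary amine without donors enters at the same saturated ring carbon. Going by the values given here, no measured pair shows the effect of such a change on maximal response. Since the three measured compounds, with their varied groups on that ring carbon, all lie within one band, the expectation for compound 4 is a step from compound 1 of a number 5 percentage points lower from compound 1 to compound 4 (within the scatter), small and not beyond the scatter. Compound 4 is estimated at 70%, in a range of 52% to 88%.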

Compound 4, largest response reached (reported as efficacy), in percent of the reference or control that the assay uses: 93%
The estimate for compound 4 lay 23 percentage points below the measured number, outside the stated range (above it).
By their numbers in this assay, from the lowest: compounds 3, 1 and 2 (each within the scatter of the next, the first and the last beyond it); then compound 4.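

In this assay, going by these compounds alone, the change at this saturated ring carbon gives a number 18 percentage points higher from compound 1 to compound 4 (beyond the scatter), so the group held here can shift the maximal response beyond the scatter, something the earlier compounds, which differ in several places at once, could not show. The step also shows that maximal response does not depend on keeping the hydroxy group, the ring-bound amine hydrogen or the two-ring (2-hydroxy-2,3-dihydro-1H-inden-1-yl)amino group, since all of them depart together in compound 4 without any loss. No measurement at hand gives a reason for the step.

Within the data shown here, with so many features changing at once, the single step does not separate the contributions of the lost hydroxy group, the tertiary amine, the extra methylene and the opened ring, and a benzylamino-methyl group without the methyl on nitrogen, or a phenethyl group in place of benzyl, would begin to divide them. Also open, going by these compounds, is whether (benzyl(methyl)amino)methyl gives a similar step when the triazole of compound 1 is replaced by the groups carried on the cores of compound 2 and compound 3.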